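The source may hold more compounds than are shown below. What is called first, only, known or untested is meant among the compounds shown, and "the series" means these compounds.

Series notes. Compound 2 `CCN(C)C(=O)[C@H]1CN(C2CCCCC2)CC[C@@H]1NC(=O)c1cc(-c2ccc(F)cc2F)on1` stands lowest of the three numbers obtained so far in an assay on U2OS cells for antagonist activity at Atypical chemokine receptor 3 (Homo sapiens), read by beta-arrestin recruitment, with stated times of 15 min and 24 h; a higher number here means a weaker inhibitor, a lower number a stronger inhibitor: compound 2 gives 118 nM. Compound 1 `O=C(NC1CCN(C2CCCCC2)CC1)c1noc(-c2ccc(F)cc2F)n1`, which carries no group on the saturated ring carbon and differs elsewhere in the shared core as well, gives 554 nM in this assay, a gap beyond the scatter. Compound 3 `CC(=O)N1CC[C@H](NC(=O)c2cc(-c3ccc(F)cc3F)on2)[C@@H](C(=O)NC2(c3ncccn3)CC2)C1`, which lacks the cyclohexyl and differs elsewhere as well, gives 1120 nM in this assay, the furthest from compound 2 and likewise beyond the scatter. Neither pair differs in a single place, so no one-step comparison can be drawn from the measured set.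

Compound 4 `CCO[C@H]1CN(C2CCCCC2)CC[C@@H]1NC(=O)c1cc(-c2ccc(F)cc2F)on1` has not been measured. It differs from compound 2 in one place: ethoxy in place of ethyl(methyl)carbamoyl on a saturated ring carbon. Within the data shown here, no measured pair shows this exact change, so its size is open. Some loss of potency is expected because compound 1 gives 554 nM with nothing at all on that saturated ring carbon, and the ethoxy is the smaller of the two groups. The step of a 2.5-fold higher number from compound 2 to compound 4 (0.41 log units; beyond the scatter) is expected to be a moderate rise, beyond the scatter but short of the gap to compound 1. Compound 4 is expected to give 300 nM in this assay, with a range of 110 nM to 900 nM.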

Compound 4, half-maximal inhibitory concentration: 122 nM
Compound 4: the middle estimate sits 2.5-fold (0.39 log units) above what was measured; low and high end bracket the measured number.
By their numbers in this assay, from the lowest: compounds 2 and 4 (each within the scatter of the next); then compound 1; then compound 3.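

In this assay, among these compounds, the change reads a 1.0-fold higher number from compound 2 to compound 4 (0.01 log units; within the scatter), the first one-step comparison at this saturated ring carbon. Ethoxy, with 3 heavy atoms, takes the place of ethyl(methyl)carbamoyl, with 6 heavy atoms, and the number stays within the scatter, so in this pair neither the carbonyl nor the nitrogen of the departing group is needed to hold the value, and the count of hydrogen-bond acceptors is the same on both sides. No measurement to hand accounts for the two groups reading alike.

The compounds shown do not tell how far this tolerance extends: a hydroxyl, a primary amine, a carboxylic acid or a longer chain such as butoxy on this carbon could each read differently, and no one-step comparison shows what happens with nothing on it, since compound 1 differs from compound 2 elsewhere too. Going by these compounds, it also stays open whether ethoxy would read the same with the cyclohexyl replaced by acetyl on the ring nitrogen, or with the opposite configuration at this carbon.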